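The source may hold more compounds than are shown below. What is called first, only, known or untested is meant among the compounds shown, and "the series" means these compounds.

Measured so far in a functional assay on MCF7 cells (Homo sapiens) for inhibition, read by MTT assay, with a stated time of 48 h, tested at 30 ug/mL; on this read-out lower numbers stand for less inhibition of growth and higher numbers for more inhibition of growth at the one concentration tested:
compound 1 `Cc1cccc2c1OCN(c1ccc3oc(-c4ccccc4)cc(=O)c3c1)C2` gives 72.4%
compound 2 `O=c1cc(-c2ccccc2)oc2ccc(N3COc4ccccc4C3)cc12` gives 68.5%
compound 3 `O=c1cc(-c2ccccc2)oc2ccc(N3COc4c(Br)cccc4C3)cc12` gives 71.6%

Compound 2 stands at the bottom of these three numbers, but the gaps are small: the step of a number 3.9 percentage points lower from compound 1 to compound 2 (within the scatter) and the step of a number 3.1 percentage points higher from compound 2 to compound 3 (within the scatter) both lie within the scatter, as does a number 0.8 percentage points lower from compound 1 to compound 3 (within the scatter). On these three figures the compounds cannot be told apart in this assay.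

Compound 4 `Cc1ccc2c(c1)CN(c1ccc3oc(-c4ccccc4)cc(=O)c3c1)CO2` arises from compound 2 by methyl in place of hydrogen on an aromatic carbon. The measured steps that bear on it are those in which a single small group on an aromatic carbon of the same fused ring was exchanged: the loss of a methyl in a number 3.9 percentage points lower from compound 1 to compound 2 (within the scatter) and the gain of a bromo in a number 3.1 percentage points higher from compound 2 to compound 3 (within the scatter). Neither moved the read-out beyond the scatter. For the measured compounds named here, the methyl in compound 4 sits on a different aromatic carbon from the one carried by compound 1, so no step in hand tests exactly this substitution; the expectation is nevertheless that adding a methyl here leaves this assay essentially unchanged, with a step of a number 1.5 percentage points higher from compound 2 to compound 4 (within the scatter) expected. Compound 4 is estimated at 70%, with a range from 60% to 80%.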

Compound 4, percent growth inhibition at one concentration: 56.9%
Beside the measured number, compound 4's estimate is 13.1 percentage points above it; the measured number lies below the stated range.
By their numbers in this assay, from the lowest: compound 4; then compounds 2, 3 and 1 (each within the scatter of the next).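

In this assay, for the compounds shown here, methyl in place of hydrogen on the aromatic carbon that is meta to a fused ring and para to a fused ring gives a number 11.6 percentage points lower from compound 2 to compound 4 (beyond the scatter), the only step in this set that passes the scatter. The fused ring therefore does not tolerate substitution equally at every aromatic carbon: the methyl step at the other carbon, a number 3.9 percentage points lower from compound 1 to compound 2 (within the scatter), and the bromo step, a number 3.1 percentage points higher from compound 2 to compound 3 (within the scatter), both stay within the scatter, while compound 1 with its methyl elsewhere gives 72.4% and compound 4 gives 56.9%. No measurement at hand accounts for this difference between the two methyl positions.

Still open, going by these compounds, is whether the drop belongs to methyl itself or to any group on this carbon; a bromo, a methoxy group or an amine at the same place would separate these two readings. Also open, on these data alone, is whether a longer chain such as ethyl here would widen the step, and, with a single tested concentration, whether the step would hold across a range of concentrations.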